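The source may hold more compounds than are shown below. What is called first, only, known or untested is meant among the compounds shown, and "the series" means these compounds.

Measured compounds in hand:
compound 1 `O=C1O[C@H]([C@@H](O)Cn2cc(CNS(=O)(=O)c3ccc(F)cc3)nn2)C(OCc2ccccc2)=C1OCc1ccccc1` — 41100 nM
compound 2 `CC(C)(C)c1cn(C[C@H](O)[C@H]2OC(=O)C(OCc3ccccc3)=C2OCc2ccccc2)nn1` — 35800 nM
compound 3 `O=C1O/C(=C\Cn2cc(-c3cccc(O)c3)nn2)C(OCc2ccccc2)=C1OCc1ccccc1` — 69800 nM

Among the compounds with values here, in a functional assay on SW-620 cells (Homo sapiens) for antiproliferative activity, read by MTT assay, with a stated time of 72 h (a higher number here means a weaker inhibitor, a lower number a stronger inhibitor), compound 2 sits at the low end of the three numbers, but every gap to it is within the scatter: compound 1 is the nearest, with a 1.1-fold lower number from compound 1 to compound 2 (0.06 log units; within the scatter) as the only one-place step, and compound 3 is the furthest, still within the scatter. Nothing in this set separates the three beyond repeat-measurement noise.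

Compound 4 `Cc1ccc(S(=O)(=O)NCc2cn(C[C@H](O)[C@H]3OC(=O)C(OCc4ccccc4)=C3OCc3ccccc3)nn2)cc1` is the next case. It differs from compound 2 by (((4-methylphenyl)sulfonyl)amino)methyl in place of tert-butyl on an aromatic carbon. Within the data shown here, the one step that bears on it is a 1.1-fold lower number from compound 1 to compound 2 (0.06 log units; within the scatter), read in reverse: replacing tert-butyl with a sulfonylaminomethyl group of this kind gave no movement beyond the scatter. Compound 1, which carries the closely related (4-fluorophenyl)sulfonyl variant, gives 41100 nM under the same conditions. No step beyond the scatter is therefore expected in this assay, in either direction.

The estimate for compound 4 is 40000 nM, with a range of 20000 nM to 80000 nM, meaning an expected step of a 1.1-fold higher number from compound 2 to compound 4 (0.05 log units; within the scatter).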

Compound 4, half-maximal inhibitory concentration: 45800 nM
Estimate against measurement, compound 4: 1.1-fold (0.06 log units) below; measured number inside the range.
By their numbers in this assay, from the lowest: compounds 2, 1, 4 and 3 (each within the scatter of the next).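

In this assay, a second sulfonylaminomethyl group on the aromatic carbon of the five-membered aromatic ring with 3 nitrogen again stays within the scatter of tert-butyl, with a 1.3-fold higher number from compound 2 to compound 4 (0.11 log units; within the scatter). The absence of a step now holds for two such groups rather than one, despite the added aromatic ring, hydrogen-bond donor and hydrogen-bond acceptors. Within the sulfonyl group's aromatic ring, the first change tested, methyl in place of fluoro, gives a 1.1-fold higher number from compound 1 to compound 4 (0.05 log units; within the scatter), also within the scatter, and no available data bear on why these numbers stay so close.

Open, as far as these compounds go, is whether an amine or a carboxylic acid on this aromatic carbon would move the number beyond the scatter. Also open, from the compounds shown here alone, is whether a methoxy group or a longer chain in place of the methyl on the sulfonyl group's aromatic ring would do so.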